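Swapping the Acid for an Amide on Compound 3

This account rests on a few compounds, and the source may have more. Where it says the series, first, only, none or still open, it means among the compounds named here.

Three close relatives sharing one cyclic core have been measured in a functional assay, tested at 2.5 mM; on this read-out lower numbers stand for less inhibition and higher numbers for more inhibition at the one concentration tested (going by the name of the read-out). Compound 1 `CC(C)C[C@@H]1NC(=O)[C@H](CS)NC1=O` gives 88.9%. Compound 2 `CC(C)C[C@@H]1NC(=O)[C@H](CCC(=O)O)NC1=O` gives 97.8%, and compound 3 `CC(C)C[C@@H]1NC(=O)[C@H](CC(=O)O)NC1=O` gives 95%. Every step among them is small: a number 8.9 percentage points higher from compound 1 to compound 2 (within the scatter), a number 6.1 percentage points higher from compound 1 to compound 3 (within the scatter) and a number 2.8 percentage points lower from compound 2 to compound 3 (within the scatter). Compound 3 thus cannot be set apart from either of the others; all three numbers sit level with one another at the single concentration tested.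

Compound 4 `CC(C)C[C@@H]1NC(=O)[C@H](CCC(N)=O)NC1=O` is the next member. It differs from compound 3 in one place: carbamoylmethyl in place of carboxy on a saturated chain carbon bound to a saturated ring carbon. Going by the values given here, no measured step exchanges this particular pair of groups, so the guidance is indirect. The steps of a number 6.1 percentage points higher from compound 1 to compound 3 (within the scatter) and a number 2.8 percentage points lower from compound 2 to compound 3 (within the scatter) show that replacing the group on this chain carbon, whether by carboxy, carboxymethyl or sulfanyl, has so far moved this assay by less than the scatter. On that basis compound 4 is expected to show no step beyond the scatter, a number 2 percentage points lower from compound 3 to compound 4 (within the scatter) being the estimated change. Compound 4 is therefore expected to give about 93% in this assay, within a range from 80% to 99%.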

Compound 4, a percentage reported as inhibition, at one concentration (the size of the read-out at that concentration, not a potency): 19%
Estimate against measurement, compound 4: 74 percentage points above; measured number below the stated range.
By their numbers in this assay, from the lowest: compound 4; then compounds 1, 3 and 2 (each within the scatter of the next).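

Compound 4 shows that this place, on a saturated chain carbon bound to a saturated ring carbon, is not indifferent to every change in this assay, as the level numbers of the three earlier compounds might have suggested. The most direct reading comes from amino in place of hydroxy on a carbonyl carbon, with a number 78.8 percentage points lower from compound 2 to compound 4 (beyond the scatter) and the chain otherwise kept, so chain length alone does not separate these two compounds. Compound 4 also falls away from the other two relatives, with a number 76 percentage points lower from compound 3 to compound 4 (beyond the scatter) for carbamoylmethyl in place of carboxy and a number 69.9 percentage points lower from compound 1 to compound 4 (beyond the scatter) for carbamoylmethyl in place of sulfanyl, which leaves it alone among the four compounds shown.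

The compounds shown leave open whether the amide at the end of the chain is the only group that gives such a low number, or whether a methyl ester, a nitrile or an amine there would do the same. They also leave open how an amide would read on the shorter chain of compound 3, and nothing available here explains the drop.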